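A carbamate in place of an ether on the coumarin core

This account rests on a few compounds, and the source may have more. Where it says the series, first, only, none or still open, it means among the compounds named here.

Compound 1 `CC(C)Oc1cc(=O)oc2cc(OCc3cccc(Cl)c3)ccc12` is the weaker of the two measured compounds in an assay on isolated protein (strain Sprague-Dawley) for inhibition of Amine oxidase [flavin-containing] B (Rattus norvegicus), read by spectrophotometry, with a stated time of 5 min (on this read-out lower numbers stand for stronger inhibition and higher numbers for weaker inhibition), where compound 1 gives 24500 nM. Going by the values given here, the only other measured compound, compound 2 `NC(=O)COc1cc(=O)oc2cc(OCc3cccc(Br)c3)ccc12`, stands far from it: in this assay compound 2 gives 8.91 nM, a difference well beyond the usual scatter. Compound 3 `CCOC(=O)Nc1cc(=O)oc2cc(OCc3cccc(Cl)c3)ccc12` has not yet been measured. It differs from compound 1 in one place: (ethoxycarbonyl)amino in place of isopropoxy on an aromatic carbon. Among the compounds with values here, no measured pair shows this exact exchange, so the step is not known. Compound 2 shows that a group carrying a hydrogen-bond donor and a carbonyl at this position can go with a much lower number, though it also differs in its halogen. On that basis a lowering of the number is expected, as a 41-fold lower number from compound 1 to compound 3 (1.61 log units; beyond the scatter). Compound 3 is estimated at 600 nM in this assay, within a range of 60 nM to 6000 nM.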

Compound 3, half-maximal inhibitory concentration: 589 nM
For compound 3 the middle estimate is 1.0-fold (0.01 log units) above the measured one; low and high end bracket the measured number.
By their numbers in this assay, from the lowest: compound 2; then compound 3; then compound 1.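

In this assay, (ethoxycarbonyl)amino in place of isopropoxy on the aromatic carbon opposite the ring oxygen gives a 42-fold lower number from compound 1 to compound 3 (1.62 log units; beyond the scatter). Going by these compounds alone, this is the first step at this position with the rest of the structure unchanged, so it shows that the position alone can move the number by a large amount, which the earlier pair could not show because its members also differ in their halogen. The entering group has more heavy atoms than isopropoxy and brings a hydrogen-bond donor, but no available evidence says what lies behind the step. As far as these compounds go, it remains open whether the nitrogen or the ethyl carbamate as a whole goes with the lower number, which a plain amine at this position would help to separate. From the compounds shown here alone, how a longer chain on the carbamate oxygen would fare also stays open.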